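Swapping a dichlorobenzyl for a chlorobenzyl on a benzothiazole urea

The source may report more compounds than this note shows. Statements on the series, on what has been measured and on what is new or still open speak of the compounds shown alone.

Measured so far:
- compound 1, `CCN(CC)Cc1ccc2nc(NC(=O)N/N=C/c3cn(Cc4ccccc4Cl)c4ccccc34)sc2c1`: 900 nM
- compound 2, `CCN(CC)Cc1ccc2nc(NC(=O)N/N=C3\C(=O)Nc4ccc(F)cc43)sc2c1`: "not determined" (no result reported)
- compound 3, `CC1CCN(Cc2ccc3nc(NC(=O)N/N=C/c4cn(Cc5ccc(Cl)cc5Cl)c5ccccc45)sc3c2)CC1`: 3140 nM

These compounds were tested in a functional assay on MDA-MB-231 cells (Homo sapiens) for cytotoxicity, read by MTT assay, with a stated time of 72 h; a higher number here means a weaker inhibitor, a lower number a stronger inhibitor. In this assay compound 1 gives 900 nM. Compound 2 was included in the series, but in this assay compound 2 gives "not determined" (no result reported), so no number was obtained for it. In this assay compound 3 gives 3140 nM, the highest of the two numbers available; compound 1 sits a good way lower, and that gap is larger than the usual scatter of this assay. Compound 1 and compound 3 differ in more than one place, so no single change can be read from their pair.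

Compound 4, `CC1CCN(Cc2ccc3nc(NC(=O)N/N=C/c4cn(Cc5cccc(Cl)c5)c5ccccc45)sc3c2)CC1`, is not yet measured. It differs from compound 3 in one place: 3-chlorophenyl in place of 2,4-dichlorophenyl on a saturated chain carbon bound to an aromatic nitrogen. Among the compounds with values here, no measured pair in this set isolates that kind of change, so there is no direct guide to its size or direction. The expectation is a modest step, a 1.4-fold lower number from compound 3 to compound 4 (0.15 log units; within the scatter), not clearly beyond the scatter, leaning slightly toward a lower number. Compound 4 is therefore estimated at 2200 nM, with a plausible range from 700 nM to 6500 nM.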

Compound 4, half-maximal inhibitory concentration: 2110 nM
The estimate for compound 4 lay 1.0-fold (0.02 log units) above the measured number, within the range that was stated.
By their numbers in this assay, from the lowest: compound 1; then compounds 4 and 3 (each within the scatter of the next).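

In this assay, going from 2,4-dichlorophenyl to 3-chlorophenyl on a saturated chain carbon bound to an aromatic nitrogen gives a 1.5-fold lower number from compound 3 to compound 4 (0.17 log units; within the scatter). Within the data shown here, this pair is the first in the set to isolate a single change at this position, with the rest of the molecule held the same. Taking the phenyl group from two chlorines to one, with a different substitution pattern, therefore produces no difference that can be told apart from ordinary assay scatter, and nothing measured here offers an explanation for this result.

As far as these compounds go, both groups in this pair carry chlorine, so it remains open how the assay would respond to a benzyl group with no chlorine at all, or to one bearing a methoxy group or a carboxylic acid instead. From the compounds shown here alone, it also remains open whether the same swap would give a similarly small step on a compound carrying the diethylaminomethyl group of compound 1 in place of the amine shared by compound 3 and compound 4.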